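This account rests on a few compounds, and the source may have more. Where it says the series, first, only, none or still open, it means among the compounds named here.

Measured compounds:
- compound 1, `O=C(O)COc1c(Cl)cc([C@H]2CC[C@]3(CC2)OOC2(O3)C3CC4CC(C3)CC2C4)cc1Cl`, 3.3
- compound 2, `O=C(O)CNC(=O)COc1ccc([C@H]2CC[C@]3(CC2)OOC2(O3)C3CC4CC(C3)CC2C4)cc1`, 3
- compound 3, `O=C(O)COc1ccc([C@H]2CC[C@]3(CC2)OOC2(O3)C3CC4CC(C3)CC2C4)cc1Cl`, 3.2

These three share one core and differ only in what hangs from the phenyl ring. In a physicochemical assay for lipophilicity, read by HPLC, at pH 7.4 (a higher number here means a more lipophilic compound, a lower number a more polar compound), compound 1 gives 3.3, compound 3 gives 3.2 and compound 2 gives 3. Within the data shown here, the one change between two measured compounds, a number 0.10 log units lower from compound 1 to compound 3 (within the scatter), is within the scatter. Compound 2 has the lowest of the three numbers, but its gaps to compound 3 and to compound 1 are both within the scatter, so the three compounds cannot be told apart on this assay.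

Compound 4, `O=C(O)c1ccc([C@H]2CC[C@]3(CC2)OOC2(O3)C3CC4CC(C3)CC2C4)cc1`, is not yet measured. It differs from compound 2 in one place: carboxy in place of ((carboxymethyl)carbamoyl)methoxy on an aromatic carbon. Among the measured compounds shown here, no measured step covers this kind of change; the only measured step concerns a chloro group and does not bear on it. The change removes an amide and an ether oxygen, along with the carbons that carried them, and leaves a carboxy directly on the ring, which is still an acid. On that reasoning compound 4 is expected to sit close to compound 2, with a step of a number 0.20 log units higher from compound 2 to compound 4 (within the scatter) that need not exceed the scatter. The estimate for compound 4 in this assay is 3.2, in a range from 2.7 to 3.7.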

Compound 4, distribution coefficient: 3
Estimate against measurement, compound 4: 0.20 log units above, within the range that was stated.
By their numbers in this assay, from the lowest: compounds 2, 4, 3 and 1 (each within the scatter of the next).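

Measured by this assay, the exchange of ((carboxymethyl)carbamoyl)methoxy for carboxy, on an aromatic carbon para to a large group, gives no change at the digits printed from compound 2 to compound 4 (within the scatter) and is the first step shown at this position, since the only earlier step concerned a chloro group. The size of the exchange makes this informative: a group of 9 heavy atoms with 2 hydrogen-bond donors and 3 hydrogen-bond acceptors gives way to one of 3 heavy atoms with 1 hydrogen-bond donor and 1 hydrogen-bond acceptor, yet this assay cannot tell the two compounds apart. So for this pair, a large difference in the group's atom count does not come with a readable difference in the number, and nothing at hand explains that outcome.

On these data alone, both groups in this step end in a carboxy group, so it remains open whether an amine, a primary amide or a simple methyl group at the same position would also stay within the scatter of compound 2. Also open, as far as these compounds go, is whether a longer chain ending in carboxy, or an ether-linked chain without the amide, would read the same way.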